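The compounds below may be only part of what the source reports. "The series", "measured", "known", "first", "only" and "open" are said of these compounds alone.

Compound 1 `Cc1cccc(-c2n[nH]cc2N2CCCNCC2)c1` and compound 2 `COc1ccc(-c2n[nH]cc2N2CCNCC2)cc1` were tested in an assay on isolated protein for binding affinity to 5-hydroxytryptamine receptor 1D (Homo sapiens); a higher number here means a weaker inhibitor, a lower number a stronger inhibitor. In this assay compound 1 gives 3290 nM. For compound 2 this assay reports only a limit, > 10000 nM. The two compounds differ in more than one place, so the gap between them cannot be tied to any single change. What can be said is that compound 2 sits at the limit of > 10000 nM in this assay, at which 1 of the 2 values shown sits.

Compound 3 `Fc1ccc(-c2n[nH]cc2N2CCNCC2)cc1` has not yet been measured. It differs from compound 2 by fluoro in place of methoxy on an aromatic carbon. With compound 2 known only as a limit, no step size can be read from the data. The step expected here, an at least 1.1-fold lower number from compound 2 to compound 3 (0.04 log units; that floor lies within the scatter), is small or none beyond the scatter. Compound 3 is therefore expected to give about 9000 nM in this assay, most likely between 2500 nM and 30000 nM.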

Compound 3, inhibition constant: > 10000 nM
Compound 3 was reported as a limit; the forecaster's own chance of this, stated with the estimate: 55%; at least 1.1-fold (0.04 log units) between middle value and limit.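

In this assay compound 2 and compound 3 are both reported only as limits, so no step can be read for fluoro in place of methoxy on an aromatic carbon. The compounds shown leave open whether this swap changes binding at all.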